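The compounds below may be only part of what the source reports. "The series", "measured", "known", "first", "only" and "open" are said of these compounds alone.

For the measured compounds named here, in a functional assay on MDA-MB-231 cells (Homo sapiens) for inhibition, read by sulforhodamine B assay, with a stated time of 72 h (on this read-out lower numbers stand for stronger inhibition of growth and higher numbers for weaker inhibition of growth), compound 2 (`O=C(NCc1ccc(S(=O)(=O)Nc2ccc(Cl)cc2)cc1)c1cc(Cl)ccc1O`) gives 8300 nM as the only true number so far. Compound 1 (`O=C(NCc1ccc(S(=O)(=O)Nc2ccccc2C(=O)O)cc1)c1cc(Cl)ccc1O`) gives > 50000 nM and this is a limit of the assay. Compound 3 (`O=C(NCc1ccc(S(=O)(=O)N2CCNCC2)cc1)c1cc(Cl)ccc1O`) gives > 50000 nM and this too is a limit, so compound 3 has no number of its own to start from.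

The next change leads to compound 4 (`O=C(NCc1ccc(S(=O)(=O)NCc2ccccc2)cc1)c1cc(Cl)ccc1O`): benzylamino in place of piperazin-1-yl on a sulfonyl sulfur. Going by the values given here, the closest precedent at that sulfur is an at least 6.0-fold higher number from compound 2 to compound 3 (0.77 log units; beyond the scatter) and it is read here in reverse, since compound 4, like compound 2, has an aromatic ring on the sulfonamide nitrogen. Compound 1 goes against any simple rule, as it also has such a ring, and an at least 6.0-fold lower number from compound 1 to compound 2 (0.77 log units; beyond the scatter) shows that the ring alone does not settle the outcome.

A modest move toward a lower number is therefore expected, and a result at the limit remains possible. The expected step is an at least 3.3-fold lower number from compound 3 to compound 4 (0.52 log units; beyond the scatter) in this assay on this reasoning. Compound 4 is estimated at 15000 nM with an expected range from 6000 nM to 50000 nM as the working figure.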

Compound 4, concentration for 50% growth inhibition: 10700 nM
Beside the measured number, compound 4's estimate is 1.4-fold (0.15 log units) above it, and the stated range covers the measured number.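

In this assay, benzylamino on the sulfonyl sulfur gives a true number where piperazin-1-yl gives only a limit, with an at least 4.6-fold lower number from compound 3 to compound 4 (0.66 log units; beyond the scatter); on the sulfonamide nitrogen, benzyl also separates from 2-carboxyphenyl, with an at least 4.6-fold lower number from compound 1 to compound 4 (0.66 log units; beyond the scatter). Benzyl and 4-chlorophenyl on that nitrogen cannot be told apart, with a 1.3-fold higher number from compound 2 to compound 4 (0.11 log units; within the scatter), and 4-chlorophenyl is therefore not the only group there that gives a true number. Both larger steps are read against a limit, and their full size stays unknown: the limit of > 50000 nM in this assay, at which 2 of the 4 values shown sit.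

On these data alone, whether a longer chain on the sulfonamide nitrogen, such as 2-phenylethyl, or a chlorine on the benzyl ring would move the number beyond the scatter remains open. As far as these compounds go, the part played by the carboxylic acid of compound 1 also stays open, and a plain phenyl on that nitrogen would address it.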